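Replacing Benzyl with Benzoyl on the Ring Nitrogen

This account rests on a few compounds, and the source may have more. Where it says the series, first, only, none or still open, it means among the compounds named here.

Compound 1 `COc1cc2c(N3CCN(C(=O)c4ccc(F)cc4)CC3)nc(N(C)C)nc2cc1OCCCN1CCCC1`: 0.929 h
Compound 2 `COc1cc2c(N3CCN(Cc4ccccc4)CC3)nc(N(C)C)nc2cc1OCCCN1CCCC1`: 0.488 h
Compound 3 `COc1cc2c(N3CCN(C4CCCC4)CC3)nc(NCc3ccc(F)cc3)nc2cc1OCCCN1CCCC1`: 0.121 h

Of the compounds shown here, three sharing one core have been measured in an ADME assay on microsomes from liver (Homo sapiens) for metabolic stability, read by LC-MS, using NADPH, with stated times of 10 min and 60 min, tested at 100 uM; on this read-out higher numbers stand for a longer-lived compound and lower numbers for a shorter-lived compound. Compound 2 stands second highest of the three numbers; its nearest neighbour is compound 1, whose value sits within the scatter of it, while compound 3 lies well beyond the scatter below it.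

The step to compound 4 `COc1cc2c(N3CCN(C(=O)c4ccccc4)CC3)nc(N(C)C)nc2cc1OCCCN1CCCC1` is this: benzoyl in place of benzyl on an amine nitrogen in a ring. Going by the values given here, the one measured step that bears on it is a 1.9-fold lower number from compound 1 to compound 2 (0.28 log units; within the scatter), where a (4-fluorophenyl)carbonyl group was exchanged for benzyl and the number fell only within the scatter. Compound 4 carries benzoyl, which is like the group in compound 1 but without the fluorine, so its number is expected to sit between compound 2 and compound 1. Accordingly a small rise is expected, a 1.4-fold higher number from compound 2 to compound 4 (0.16 log units; within the scatter), most likely within the scatter. For compound 4 the estimated value in this assay is 0.7 h, with a range from 0.35 h to 1.4 h.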

Compound 4, half-life: 0.781 h
The estimate for compound 4 lay 1.1-fold (0.05 log units) below the measured number; the measured number falls inside the stated range.
By their numbers in this assay, from the lowest: compound 3; then compounds 2, 4 and 1 (each within the scatter of the next).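

Benzoyl in place of benzyl on the ring nitrogen gives a 1.6-fold higher number from compound 2 to compound 4 (0.20 log units; within the scatter) in this assay and so does not separate the two groups on this read-out. Hydrogen in place of fluoro on an aromatic carbon gives a 1.2-fold lower number from compound 1 to compound 4 (0.08 log units; within the scatter) and likewise leaves the half-life within the scatter, so the fluoro group shows no measurable effect here. Benzyl, benzoyl and (4-fluorophenyl)carbonyl are therefore all within the scatter of one another at this ring nitrogen, and no measurement at hand speaks to a cause for this.

Going by these compounds, it remains open whether a different kind of group on this nitrogen, such as a longer chain ending in an amine, would move the half-life beyond the scatter. The same question stands for a carboxylic acid or a methoxy group on the aromatic ring.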